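The source may hold more compounds than are shown below. What is called first, only, known or untested is meant among the compounds shown, and "the series" means these compounds.

Measured so far:
- compound 1 `Oc1cncc(N2CCCNCC2)c1`: 120%
- compound 2 `Oc1cc(N2CCCNCC2)cnc1I`: 104%

In an assay on HEK293 cells with Neuronal acetylcholine receptor; alpha4/beta2 (Homo sapiens) as the target, read by FLIPR and calcium flux (a lower number here means a smaller maximal response, a higher number a larger maximal response), compound 1 stands highest of the two numbers recorded; its nearest neighbour is compound 2, and the step of a number 16 percentage points lower from compound 1 to compound 2 (beyond the scatter) lies beyond the scatter, with iodo in place of hydrogen on an aromatic carbon as the only difference.

Compound 3 `C=COc1cncc(N2CCCNCC2)c1` is not yet measured. Against compound 1 the change is vinyl in place of hydrogen on an oxygen on an aromatic ring; read one bond further out it is hydroxy to vinyloxy.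

For the measured compounds named here, the one measured step, from compound 1 to compound 2, alters an aromatic carbon and leaves the oxygen untouched, so it offers no direct guide to a change on the oxygen; it shows only that a single substitution on this core can move the maximal response by a modest amount. With nothing closer to lean on, the working expectation is a modest loss from compound 1 to compound 3, a number 20 percentage points lower from compound 1 to compound 3 (beyond the scatter), with a wide margin in either direction.

For compound 3 the estimated value in this assay is 100%, expected to fall between 70% and 125%.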

Compound 3, largest response reached (reported as efficacy), in percent of the reference or control that the assay uses: 61%
Estimate against measurement, compound 3: 39 percentage points above; measured number outside the range, below it.
By their numbers in this assay, from the lowest: compound 3; then compound 2; then compound 1.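

For the compounds shown here, changing hydroxy to vinyloxy on the oxygen on the aromatic ring gives the first reading at this position, and in this assay the result is a number 59 percentage points lower from compound 1 to compound 3 (beyond the scatter) as a large step. Going by these compounds alone, the only other single change on the core of compound 1, iodo in place of hydrogen on an aromatic carbon, gives the modest a number 16 percentage points lower from compound 1 to compound 2 (beyond the scatter) so of the two places changed so far, the oxygen shows the greater sensitivity, although compound 3 still reaches 61% and keeps part of the maximal response. No available measurement bears on the reason for this drop.

As far as these compounds go, it remains open whether the loss follows the removal of the hydrogen on that oxygen or the presence of the vinyl itself, and a methoxy or ethoxy group on the same oxygen would be needed to separate the two. From the compounds shown here alone, it is also open whether an amine or a fluorine atom in place of the hydroxy would hold the response near that of compound 1 (120%).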